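Adding a hydroxy group to a propylamide macrolide

The source may hold more compounds than are shown below. What is called first, only, known or untested is meant among the compounds shown, and "the series" means these compounds.

Measured so far:
- compound 1 `COC(=O)C[C@@H]1C[C@@]2(CO2)[C@H](O)[C@@H](/C=C/C(C)=C/C[C@@H]2O[C@H](C)[C@H](NC(=O)/C=C\[C@H](C)OC(C)=O)C[C@@H]2C)O1`: 2.23
- compound 2 `CCCNC(=O)C[C@@H]1C[C@@]2(CO2)C[C@@H](/C=C/C(C)=C/C[C@@H]2O[C@H](C)[C@H](NC(=O)/C=C\[C@H](C)OC(C)=O)C[C@@H]2C)O1`: 3.72

Of the compounds shown here, two have been measured in a physicochemical assay for lipophilicity, using the shake flask method, measured as octanol-water partition, at pH 7.4; on this read-out higher numbers stand for higher lipophilicity and lower numbers for lower lipophilicity. Compound 2 stands highest of the two numbers: its nearest neighbour is compound 1, whose value lies beyond the usual scatter below it. Compound 1 and compound 2 differ in more than one place, so the two values can only be set side by side, not traced to a single change.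

Compound 3 `CCCNC(=O)C[C@@H]1C[C@@]2(CO2)[C@H](O)[C@@H](/C=C/C(C)=C/C[C@@H]2O[C@H](C)[C@H](NC(=O)/C=C\[C@H](C)OC(C)=O)C[C@@H]2C)O1` has not yet been measured in this assay. It differs from compound 2 in one place: hydroxy in place of hydrogen on a saturated ring carbon. The hydroxy group enters on a saturated ring carbon of the six-membered non-aromatic ring with one oxygen, two ring bonds from the ring oxygen.

Among the compounds with values here, since no single-change step between measured compounds is available, the expectation rests on what the two values show. Compound 1, which carries the hydroxy group with a different chain, gives 2.23. For compound 3 a downward step of a number 0.72 log units lower from compound 2 to compound 3 (beyond the scatter) is expected, clearly beyond the scatter. Compound 3 is estimated at 3, in a range from 2.4 to 3.5.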

Compound 3, distribution coefficient: 2.22
Compound 3: the middle estimate sits 0.78 log units above what was measured; measured number below the stated range.
By their numbers in this assay, from the lowest: compounds 3 and 1 (each within the scatter of the next); then compound 2.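

In this assay, within the data shown here, hydroxy in place of hydrogen on the saturated ring carbon, two ring bonds from the ring oxygen, gives a large step (a number 1.50 log units lower from compound 2 to compound 3 (beyond the scatter)), the first reading of a single change at this position. The second single change, propylamino in place of methoxy on a carbonyl carbon, gives a step that lies within the scatter (a number 0.01 log units lower from compound 1 to compound 3 (within the scatter)), so with the hydroxy group present, these two ends of the chain cannot be told apart on this read-out. Nothing measured here explains either result.

The hydroxy step is read on the propylamide alone, so the compounds shown cannot say whether a step of similar size would appear with methoxy on the carbonyl carbon. From the compounds shown here alone, it also remains open where an amine on the same saturated ring carbon would fall, or how a longer chain or a carboxylic acid at the carbonyl end would compare.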